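This account rests on a few compounds, and the source may have more. Where it says the series, first, only, none or still open, it means among the compounds named here.

Compound 3 `COc1ccc(F)cc1CNCCCNc1ccnc2cc(-c3ccccc3)ccc12` is the starting point of this step. In a physicochemical assay for acid dissociation, compound 3 gives 9.47, level at the digits shown with compound 2 `COc1ccc(F)cc1CNCCCNc1ccnc2cc(CCc3ccccc3)ccc12`, which gives 9.47, while compound 1 `COc1cccc(Oc2ccc3c(NCCCNCc4cc(F)ccc4OC)ccnc3c2)c1` gives 9.28. The three numbers lie within the scatter of one another: a number 0.19 log units higher from compound 1 to compound 2 (within the scatter), a number 0.19 log units higher from compound 1 to compound 3 (within the scatter) and no change at the digits printed from compound 2 to compound 3 (within the scatter). Each of these steps exchanges the whole substituent on the same aromatic carbon of the shared core, from 3-methoxyphenoxy to phenethyl or phenyl, without moving the readout.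

Compound 4 `COc1ccc(-c2ccc3c(NCCCNCc4cc(F)ccc4OC)ccnc3c2)cc1` differs from compound 3 by methoxy in place of hydrogen on an aromatic carbon; cut one bond further out, the same difference reads phenyl to 4-methoxyphenyl. Among the measured compounds shown here, no measured step here adds a methoxy group to an outer ring, but the larger exchanges already seen at this carbon of the core all stayed within the scatter, so a step no larger than the scatter is expected, no change at the digits printed from compound 3 to compound 4 (within the scatter). Compound 4 is therefore estimated at 9.47, between 9.2 and 9.75.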

Compound 4, acid dissociation constant: 9.47
Beside the measured number, compound 4's estimate shows no gap at the digits printed; low and high end bracket the measured number.
By their numbers in this assay, from the lowest: compounds 1, 2, 3 and 4 (each within the scatter of the next).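

In this assay, among the compounds shown here, methoxy in place of hydrogen on the outer phenyl ring, para to a large group, gives no change at the digits printed from compound 3 to compound 4 (within the scatter) and so extends the flat picture to a change on that ring itself, whereas the earlier steps exchanged the whole substituent on the core. The other two comparisons agree, with 4-methoxyphenyl in place of phenethyl giving no change at the digits printed from compound 2 to compound 4 (within the scatter) and 4-methoxyphenyl in place of 3-methoxyphenoxy giving a number 0.19 log units higher from compound 1 to compound 4 (within the scatter) so that all four compounds stand within the scatter of one another. No measurement shown here accounts for this flat readout.

As far as these compounds go, it remains open whether an amine or a carboxylic acid on the outer ring would also stay within the scatter. From the compounds shown here alone, whether a change to the shared core itself, rather than to this substituent, would move the number also remains open.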